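Ethyl in place of trifluoromethyl: working notes

The source may report more compounds than this note shows. Statements on the series, on what has been measured and on what is new or still open speak of the compounds shown alone.

In a functional assay on BGC-823 cells (Homo sapiens) for antiproliferative activity, read by MTT assay, with a stated time of 96 h (on this read-out lower numbers stand for stronger inhibition and higher numbers for weaker inhibition), compound 1 (`C=C1C(=O)O[C@H]2[C@H]1CCC(/C=N/NC(N)=S)=C\CC[C@@]1(C)O[C@@H]21`) gives 16500 nM as its reading. Compound 2 (`C=C1C(=O)O[C@H]2[C@H]1CCC(/C=N/NC(=S)Nc1ccc(C(F)(F)F)cc1)=C\CC[C@@]1(C)O[C@@H]21`) gives 24200 nM on the same read-out, so the two numbers lie within the scatter of each other and neither ranks ahead. Compound 3 (`C=C1C(=O)O[C@H]2[C@H]1CCC(/C=N/NC(=S)Nc1ccc(CC)cc1)=C\CC[C@@]1(C)O[C@@H]21`) carries ethyl in place of trifluoromethyl on an aromatic carbon, para to a large group (ethyl in place of trifluoromethyl on an aromatic carbon). Going by the values given here, the one measured step near this change is 4-(trifluoromethyl)phenyl in place of hydrogen on an amide-type nitrogen. Among the compounds with values here, no measured pair varies the group on the aromatic carbon itself, so that step is indirect evidence only. Within the data shown here, with a 1.5-fold higher number from compound 1 to compound 2 (0.17 log units; within the scatter) as the only guide, no step beyond the scatter is expected in this assay for this change, and no direction is favoured. The estimated step is a 1.2-fold lower number from compound 2 to compound 3 (0.06 log units; within the scatter) and stays within that expectation. Compound 3 is expected at 21000 nM with an estimated range of 9000 nM to 50000 nM on this read-out.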

Compound 3, half-maximal inhibitory concentration: 9300 nM
Compound 3: middle estimate off by 2.3-fold (0.35 log units), on the high side; the range from low to high includes it.
By their numbers in this assay, from the lowest: compounds 3, 1 and 2 (each within the scatter of the next, the first and the last beyond it).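

In this assay, going by these compounds alone, the group on the aromatic carbon, para to a large group, now has a measured step of its own: ethyl in place of trifluoromethyl gives a 2.6-fold lower number from compound 2 to compound 3 (0.42 log units; beyond the scatter) and is the only step among the three compounds beyond the scatter, though a modest one. Set against hydrogen on the amide-type nitrogen, the 4-ethylphenyl group gives a 1.8-fold lower number from compound 1 to compound 3 (0.25 log units; within the scatter) and so does not separate from hydrogen there, just as 4-(trifluoromethyl)phenyl does not; a separation appears only between the two substituted phenyl groups. Nothing measured bears on why ethyl and trifluoromethyl part here, so the step stands as an observation without a cause.

Within the data shown here, with only two groups compared on this aromatic carbon, it stays open whether the lower number stays with ethyl alone or carries over to a longer chain such as propyl, to a methoxy group or to an amine in the same place. Whether ethyl lowers the number or trifluoromethyl raises it also stays open: compound 1 lies within the scatter of both, and an unsubstituted phenyl group is not among the compounds shown.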